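A few compounds are considered here, and "the series" means these few. Any claim that something is new, unique, unknown or untested is made for them only; others in the source may bear on it.

Of the compounds shown here, three have numbers so far in a functional assay on HCT-116 cells (Homo sapiens) for antiproliferative activity, read by sulforhodamine B assay, with a stated time of 48 h; a lower number here means a stronger inhibitor, a higher number a weaker inhibitor. Compound 1 (`COc1cc(O)c(C(=O)/C=C/c2ccc(F)cc2)c(OC)c1`) gives 4400 nM, compound 2 (`COc1cc(O)c(C(=O)/C=C/c2cc(Cl)cc(Cl)c2)c(OC)c1`) gives 1900 nM, and compound 3 (`COc1ccc(/C=C/C(=O)c2c(OC)cc(OC)cc2OCC=C(C)C)cc1`) gives 7600 nM. Compound 3 stands level with compound 1 within the scatter, while its number is higher than that of compound 2 by a gap beyond the scatter. Going by the values given here, no two measured compounds differ in one place only, so the series offers no direct measure of any single structural change.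

Compound 4 (`COc1cccc(/C=C/C(=O)c2c(OC)cc(OC)cc2OCC=C(C)C)c1`) has no number yet. It has the same atoms as compound 3, joined differently, with 3-methoxyphenyl in place of 4-methoxyphenyl on a double-bonded chain carbon bound to a double-bonded chain carbon.

Among the compounds with values here, with no measured step to draw on, the expectation rests on compound 3 at 7600 nM and on the matching counts of the two groups. No change beyond the scatter is expected in this assay, and no direction can be firmly assigned. The expected step, a 1.3-fold lower number from compound 3 to compound 4 (0.10 log units; within the scatter), is therefore small. For compound 4 the estimated value is 6000 nM, with an expected range of 2500 nM to 14000 nM.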

Compound 4, half-maximal inhibitory concentration: 7700 nM
Beside the measured number, compound 4's estimate is 1.3-fold (0.11 log units) below it, within the range that was stated.
By their numbers in this assay, from the lowest: compound 2; then compounds 1, 3 and 4 (each within the scatter of the next).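

In this assay, going by these compounds alone, 3-methoxyphenyl in place of 4-methoxyphenyl on a double-bonded chain carbon bound to a double-bonded chain carbon gives a 1.0-fold higher number from compound 3 to compound 4 (0.01 log units; within the scatter) as the first step that can be read at a single place. At this place the two methoxyphenyl groups therefore cannot be told apart in this read-out, with the rest of the structure held fixed, and this finding covers this pair alone and cannot be carried over to the other compounds. Nothing at hand bears on why the two groups give matching results.

As far as these compounds go, whether a methoxy group at this place matters at all stays open, as both compounds carry one: a plain phenyl, a 4-hydroxyphenyl or a 4-dimethylaminophenyl on the same double-bonded chain carbon would test that. Also open, from the compounds shown here alone, is what the ether chain shared by compound 3 and compound 4 contributes, which a free hydroxyl or a shorter allyl ether in its place would show.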